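The source may report more compounds than this note shows. Statements on the series, on what has been measured and on what is new or still open speak of the compounds shown alone.

Working notes on the series. In a functional assay on MCF7 cells (Homo sapiens) for cytotoxicity, read by MTT assay, with a stated time of 72 h (a lower number here means a stronger inhibitor, a higher number a weaker inhibitor), compound 1 `CNC(=O)c1cc(Oc2ccc(C3=NNC(c4ccc([N+](=O)[O-])cc4)C3)cc2)ccn1` has no single number to stand on, and its entry reads "not determined" (no result reported). Compound 3 `CNC(=O)c1cc(Oc2ccc(C3=NNC(c4ccc(Cl)c(Cl)c4)C3)cc2)ccn1` is in the same position, with "not determined" (no result reported). Going by the values given here, the only number comes from compound 2 `CNC(=O)c1cc(Oc2ccc(C3=NNC(c4ccc(OC)cc4)C3)cc2)ccn1`, which gives 11000 nM.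

The step followed here leads to the unmeasured compound 4 `CNC(=O)c1cc(Oc2ccc(C3=NNC(c4ccc(F)cc4)C3)cc2)ccn1`. The change is fluoro in place of nitro on an aromatic carbon of a six-membered aromatic ring of carbon only, para to a large group, so 4-nitrophenyl to 4-fluorophenyl. The rest of the core of compound 1 stays the same.

Among the compounds with values here, no measured step exists, so the size of this change in this assay cannot be read from the data. No step beyond the scatter is expected, and no direction is favoured. The expectation rests on compound 2 at 11000 nM, with a wide margin for a single reference point. For compound 4 the expected value is 9000 nM, with an estimated range of 3000 nM to 27000 nM.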

Compound 4, half-maximal inhibitory concentration: 9480 nM
Estimate against measurement, compound 4: 1.1-fold (0.02 log units) below; low and high end bracket the measured number.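

Compound 4 gives the series its first readable step at this position: in this assay, the step is a 1.2-fold lower number from compound 2 to compound 4 (0.06 log units; within the scatter), so the two compounds lie within the scatter of each other. Steps involving compound 1 or compound 3 cannot be read, as neither has a single number, and the change from 4-nitrophenyl to 4-fluorophenyl therefore remains without a measured size. No measurement available here accounts for this result.

Going by these compounds, whether a different group at this position, such as an amine or a carboxylic acid, would give a step beyond the scatter stays open. The compounds shown also say nothing about changes to the shared core.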